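The compounds below may be only part of what the source reports. "The series", "measured", "known", "first", "only" and "open" are said of these compounds alone.

Measured compounds:
- compound 1 `COc1ccc(/C=C\C(=O)O)c(OCc2cn(-c3ccc(NC(C)=O)cc3)nn2)c1CC=C(C)C`: "not determined" (no result reported)
- compound 2 `COc1ccccc1-n1cc(COc2c(/C=C\C(=O)O)ccc(OC)c2CC=C(C)C)nn1`: 32200 nM

Going by the values given here, only two compounds have been through a functional assay on HCT-116 cells (Homo sapiens) for cytotoxicity, read by MTT assay, with a stated time of 24 h (on this read-out higher numbers stand for weaker inhibition and lower numbers for stronger inhibition), so far, and only one of them came back with a number. Compound 1 was taken into this assay, but the entry for compound 1 reads "not determined" (no result reported), so there is no single number to mark where it stands. Compound 1 carries an acetamidophenyl on the triazole ring where a methoxyphenyl stands in compound 2; in this assay compound 2 gives 32200 nM.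

Compound 3 `COc1ccc(/C=C\C(=O)O)c(OCc2cn(-c3ccc(NC(=O)c4ccccc4)cc3)nn2)c1CC=C(C)C` is the next compound to be tested. It differs from compound 1 in one place: phenyl in place of methyl on a carbonyl carbon. Among the compounds with values here, without a measured starting point for compound 1, and with no measured pair that shows what such a change does, there is no step to quote and no direction to lean on. Within the data shown here, the one available value belongs to compound 2, which shares the core and the triazole linker, and that is the only anchor.

On that basis compound 3 is expected to come out at about 30000 nM in this assay, with a plausible range from 7000 nM to 130000 nM.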

Compound 3, half-maximal inhibitory concentration: 16400 nM
Estimate against measurement, compound 3: 1.8-fold (0.26 log units) above; the range from low to high includes it.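

Going by these compounds alone, compound 1 has no single number in this assay, and no step to compound 3 can be read from it. The compounds shown leave open what the change from acetamido to benzamido does on this read-out. No measured evidence bears on the result for compound 3.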